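Amide side chains on the shared core: the next step

The source may report more compounds than this note shows. Statements on the series, on what has been measured and on what is new or still open speak of the compounds shown alone.

Measured in a functional assay on A-375 cells (Homo sapiens) for inhibition, read by MTT assay, with a stated time of 120 h; a higher number here means a weaker inhibitor, a lower number a stronger inhibitor:
- compound 1 `CNC(=O)/C=C/c1ccc(NC(=O)Nc2ccc(Cl)c(C(F)(F)F)c2)cc1`: 20900 nM
- compound 2 `CNC(=O)c1cccc(-c2ccc(NC(=O)Nc3ccc(Cl)c(C(F)(F)F)c3)cc2)c1`: 46500 nM

Compound 2 has the higher number of the pair at 46500 nM, and compound 1 is its nearest neighbour. The next compound is compound 3 `O=C(CCc1ccc(NC(=O)Nc2ccc(Cl)c(C(F)(F)F)c2)cc1)NC1CCC1`, with this change: 2-(cyclobutylcarbamoyl)ethyl in place of 3-(methylcarbamoyl)phenyl on an aromatic carbon. Among the measured compounds shown here, the only measured step that bears on it is a 2.2-fold higher number from compound 1 to compound 2 (0.35 log units; beyond the scatter), a modest one that brought in the 3-(methylcarbamoyl)phenyl group. Compound 3 gives up that aromatic group and, like compound 1, carries an open carbamoyl chain. For the measured compounds named here, no measured compound has the cyclobutyl group, so the range stays wide. A modest step to a lower number in this assay is therefore expected, roughly reversing the measured one. The estimated move is a 2.1-fold lower number from compound 2 to compound 3 (0.33 log units; beyond the scatter). For compound 3 the expected value is 22000 nM, with an estimated range of 8000 nM to 55000 nM.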

Compound 3, half-maximal inhibitory concentration: > 50000 nM
Compound 3 ended at the assay's limit; the forecaster's own chance of this, stated with the estimate: 10%; middle value at least 2.2-fold (0.35 log units) from the limit.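

In this assay compound 3 stands at a limit of the assay, not at a number: the limit of > 50000 nM in this assay, at which 1 of the 3 values shown sits. On this aromatic carbon, 2-(cyclobutylcarbamoyl)ethyl in place of 2-(methylcarbamoyl)ethenyl gives an at least 2.3-fold higher number from compound 1 to compound 3 (0.37 log units; beyond the scatter), so an open carbamoyl chain alone does not hold the earlier level. The exchange for 3-(methylcarbamoyl)phenyl gives an at least 1.0-fold higher number from compound 2 to compound 3 (0.03 log units; that floor lies within the scatter), so no order between these two groups can be stated.

The change from the ethenyl chain to the cyclobutyl ethyl chain alters both the chain and the amide substituent, and the compounds shown do not separate the two; 2-(methylcarbamoyl)ethyl would isolate the chain. Also open, as far as these compounds go, is how a carboxylic acid or an amine at the end of this chain would read in this assay.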